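A few compounds are considered here, and "the series" means these few. Any claim that something is new, unique, unknown or untested is made for them only; others in the source may bear on it.

Compound 3, `COc1ncc(-c2ccc3ncnc(Nc4cnn(CCCO)c4)c3c2)cc1NS(=O)(=O)c1ccc(F)cc1F`, gives 480 nM in a functional assay on HCT-116 cells (Homo sapiens) for antiproliferative activity, read by sulforhodamine B assay, with a stated time of 72 h (a lower number here means a stronger inhibitor, a higher number a weaker inhibitor), the lowest of the two numbers available, with compound 2, `COC(=O)Cn1cc(Nc2ncnc3ccc(-c4cnc(OC)c(NS(=O)(=O)c5ccc(F)cc5F)c4)cc23)cn1`, giving 1260 nM. Compound 1, `CCCCS(=O)(=O)Nc1cc(-c2ccc3ncnc(Nc4ccc(OCCO)nc4)c3c2)cnc1OC`, reaches only the limit of > 20000 nM in this assay. Going by the values given here, the one measured step, a 2.6-fold lower number from compound 2 to compound 3 (0.42 log units; beyond the scatter), changed a chain on a pyrazole. Compound 4, `COc1ncc(-c2ccc3ncnc(Nc4ccc(OCCO)nc4)c3c2)cc1NS(=O)(=O)c1ccc(F)cc1F`, differs from compound 3 at another place: 6-(2-hydroxyethoxy)pyridin-3-yl in place of 1-(3-hydroxypropyl)-1H-pyrazol-4-yl on a nitrogen on an aromatic ring. Among the compounds with values here, no measured step bears directly on this change; compound 1 carries the same entering group but a different sulfonamide, and its value is a limit, so only the sign of that change is informative. A weakening is therefore expected, estimated as a 3.1-fold higher number from compound 3 to compound 4 (0.49 log units; beyond the scatter), giving compound 4 an estimated 1500 nM, between 300 nM and 8000 nM.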

Compound 4, half-maximal inhibitory concentration: 2340 nM
For compound 4 the middle estimate is 1.6-fold (0.19 log units) below the measured one; the range from low to high includes it.
By their numbers in this assay, from the lowest: compound 3; then compounds 2 and 4 (each within the scatter of the next). At a limit, above all of these: compound 1.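

In this place on the nitrogen, 6-(2-hydroxyethoxy)pyridin-3-yl does worse than 1-(3-hydroxypropyl)-1H-pyrazol-4-yl, with a 4.9-fold higher number from compound 3 to compound 4 (0.69 log units; beyond the scatter), yet it cannot be told apart from the methoxycarbonyl pyrazole group, with a 1.9-fold higher number from compound 2 to compound 4 (0.27 log units; within the scatter). With that pyridine group held fixed, 2,4-difluorophenyl in place of butyl on the sulfonyl sulfur gives an at least 8.5-fold lower number from compound 1 to compound 4 (0.93 log units; beyond the scatter), a step read from a limit of the assay in compound 1. Nothing shown explains either change. Still open, from the compounds shown here alone, is whether an amine or a carboxylic acid in place of the hydroxyl would shift these numbers. Going by these compounds, a longer chain on the pyrazole is equally open.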